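The compounds below may be only part of what the source reports. "The series", "measured", "known", "first", "only" and "open" are said of these compounds alone.

Within the data shown here, in a functional assay on THP-1 cells (Homo sapiens) for inhibition, read by sulforhodamine B assay, with a stated time of 48 h, tested at 50 uM (on this read-out higher numbers stand for more inhibition of growth at the one concentration tested and lower numbers for less inhibition of growth), compound 1 `COc1cc(/C=C/C(=O)/C=C/c2cccc3ccccc23)ccc1OCc1cn(CCOc2cc(=O)oc3ccccc23)nn1` gives 89%, the highest of the three numbers measured so far and beyond the scatter from both others. Compound 2 `COc1ccccc1/C=C/C(=O)/C=C/c1ccc(OCc2cn(CCCOc3cc(=O)oc4ccccc34)nn2)c(OC)c1` gives 50%, and compound 3 `COc1ccccc1/C=C/C(=O)/C=C/c1ccc(OCc2cn(CCCCCOc3cc(=O)oc4ccccc34)nn2)c(OC)c1` gives 37%. No two of these three compounds differ in one place only, so none of them isolates a single change.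

Compound 4 `COc1cc(/C=C/C(=O)/C=C/c2ccco2)ccc1OCc1cn(CCOc2cc(=O)oc3ccccc23)nn1` keeps the rest of compound 1 and changes one end of the molecule: furan-2-yl in place of naphthalen-1-yl on a double-bonded chain carbon bound to a double-bonded chain carbon. Put simply, furan-2-yl stands in place of naphthalen-1-yl on a double-bonded chain carbon bound to a double-bonded chain carbon.

The data do not show what this exchange does on its own, so any expectation is uncertain. Neither compound 2 at 50% nor compound 3 at 37% carries naphthalen-1-yl, and both sit well under compound 1, which points to a fall. In this assay, the expected change is a moderate drop beyond the scatter, with an estimated step of a number 29 percentage points lower from compound 1 to compound 4 (beyond the scatter). For compound 4 the estimated value is 60%, within an expected range from 35% to 86%.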

Compound 4, percent growth inhibition at one concentration: 78%
Beside the measured number, compound 4's estimate is 18 percentage points below it; measured number inside the range.
By their numbers in this assay, from the lowest: compound 3; then compound 2; then compound 4; then compound 1.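

In this assay, furan-2-yl in place of naphthalen-1-yl gives a number 11 percentage points lower from compound 1 to compound 4 (beyond the scatter), so this end of the molecule does influence growth inhibition, though the step is modest. The earlier compounds shown here could not separate this end from their other differences, whereas this pair isolates it and shows that compound 4 still reaches 78% with one five-membered aromatic ring instead of two six-membered aromatic rings of carbon only. Nothing available explains why the number moves in this way.

From the compounds shown here alone, it remains open whether a plain phenyl ring, or a ring carrying an amine or a carboxylic acid, would keep the number near that of compound 1 or compound 4 at this place. A single concentration also leaves open how these two compounds would compare at lower concentrations.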